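The source may report more compounds than this note shows. Statements on the series, on what has been measured and on what is new or still open speak of the compounds shown alone.

Among the compounds with values here, in a functional assay on a cell-free system (plasma, Oryctolagus cuniculus) for inhibition, with stated times of 5 min, 1 min and 6 min (a lower number here means a stronger inhibitor, a higher number a weaker inhibitor), compound 1 `CCOC(=O)c1c(C)nc(-c2cccc(C#N)c2)n1O` gives 17600 nM, while compound 2 `CCOC(=O)c1c(C)nc(-c2cccc(C#N)c2)n1C(C)C` gives 9260 nM, the lowest of the two numbers, with the single step of a 1.9-fold lower number from compound 1 to compound 2 (0.28 log units; within the scatter) connecting them. Compound 3 `CCOC(=O)c1c(C)nc(-c2cccc(C#N)c2)n1OCc1ccc(F)cc1` carries (4-fluorobenzyl)oxy in place of isopropyl on an aromatic nitrogen. Within the data shown here, only the step from compound 1 to compound 2 bears on this change, and it stayed within the scatter; no measured step covers a group of this size on the ring nitrogen. The author therefore expects for compound 3 an estimated step of a 1.5-fold lower number from compound 2 to compound 3 (0.19 log units; within the scatter), not clearly beyond the scatter. Compound 3 is estimated at 6000 nM, expected between 1500 nM and 30000 nM.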

Compound 3, half-maximal inhibitory concentration: 5880 nM
Compound 3: middle estimate off by 1.0-fold (0.01 log units), on the high side; measured number inside the range.
By their numbers in this assay, from the lowest: compounds 3, 2 and 1 (each within the scatter of the next, the first and the last beyond it).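

In this assay, the aromatic nitrogen carries (4-fluorobenzyl)oxy, a far larger group with its own aromatic ring, and replacing isopropyl with it gives a 1.6-fold lower number from compound 2 to compound 3 (0.20 log units; within the scatter), so the added size costs nothing measurable here. Placing 4-fluorobenzyl on the oxygen of the hydroxy group gives a 3.0-fold lower number from compound 1 to compound 3 (0.48 log units; beyond the scatter), the first change in this small set beyond the scatter, though a modest one. Nothing measured here explains this difference.

Going by these compounds, it remains open what the fluorine contributes, since a plain benzyloxy group would be needed to separate it from the benzyl part. On these data alone, how a longer chain or an amine on this nitrogen would compare also stays unknown.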